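Smaller amine substituents in the shared core

The source may hold more compounds than are shown below. What is called first, only, known or untested is meant among the compounds shown, and "the series" means these compounds.

Compound 1 `COc1ccc(CCCNCc2c(OC)cc(Oc3ccc(Nc4ccccc4)cc3)cc2OC)cc1` in a functional assay on HCT-116 cells (Homo sapiens) for inhibition, read by MTT assay, with a stated time of 72 h (on this read-out lower numbers stand for stronger inhibition and higher numbers for weaker inhibition), gives 3230 nM. Compound 2 `COc1cc(Oc2cccc(Nc3ccccc3)c2)cc(OC)c1CNCc1ccc(Br)cc1` gives 6230 nM, the highest of the two numbers, with compound 1 nearest and within the scatter. Compound 3 `COc1cc(Oc2cccc(Nc3ccccc3)c2)cc(OC)c1CNC1CC1` in this assay reports a limit, > 20000 nM. The step of an at least 3.2-fold higher number from compound 2 to compound 3 (0.50 log units; beyond the scatter) moves toward the limit of > 20000 nM in this assay, at which 1 of the 3 values shown sits, when the amine substituent is made smaller. Compound 4 `CNCc1c(OC)cc(Oc2cccc(Nc3ccccc3)c2)cc1OC` differs from compound 2 by hydrogen in place of 4-bromophenyl on a saturated chain carbon bound to an amine nitrogen. This change also shrinks the group on the amine nitrogen, so the step of an at least 3.2-fold higher number from compound 2 to compound 3 (0.50 log units; beyond the scatter) is the one that bears on it, and a step of comparable size toward a higher number is expected. The expected step is a 2.9-fold higher number from compound 2 to compound 4 (0.46 log units; beyond the scatter). Compound 4 is expected to give 18000 nM, within 6000 nM to 60000 nM, possibly reported only as a limit.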

Compound 4, half-maximal inhibitory concentration: > 20000 nM
Compound 4: only a limit was reported; the forecaster's own chance of this, stated with the estimate: 50%; at least 1.1-fold (0.04 log units) between middle value and limit.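

Methyl in place of 4-bromobenzyl on the amine nitrogen also takes the shared core out of the measurable range in this assay: an at least 3.2-fold higher number from compound 2 to compound 4 (0.50 log units; beyond the scatter). Compound 4 reports only a limit, > 20000 nM. The loss is therefore not particular to cyclopropyl, and with methyl as with cyclopropyl the series sits at the limit: the limit of > 20000 nM in this assay, at which 2 of the 4 values shown sit.

The two limits leave the step from compound 3 to compound 4 unreadable. As far as these compounds go, whether a plain benzyl or a butyl chain on the amine nitrogen would give a measurable number remains open.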